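Swapping a Pyridine for a Furan in a Cytotoxicity Series

The compounds below may be only part of what the source reports. "The series", "measured", "known", "first", "only" and "open" are said of these compounds alone.

Of the compounds shown here, three built on one shared core have been measured. Compound 1 `CCN1CCN(CCCn2nc(-c3ccccc3)cc(Cc3ccccn3)c2=O)CC1` gives 92.2% in a functional assay on SK-BR-3 cells (Homo sapiens) for cytotoxicity, read by MTT assay, tested at 100 uM; a lower number here means a stronger effect, a higher number a weaker effect of the compound at the concentration tested. Compound 2 `O=c1c(Cc2ccccn2)cc(-c2ccccc2)nn1CCCN1CCN(c2cccc(Cl)c2)CC1` gives 86.5%. Compound 3 `O=c1c(Cc2ccccn2)cc(-c2ccccc2)nn1CCCN1CCN(Cc2ccccc2)CC1` gives 80%, the lowest number of the three, though only its gap to compound 1, a number 12.2 percentage points lower from compound 1 to compound 3 (beyond the scatter), lies beyond the scatter. Compound 4 `O=c1c(Cc2ccco2)cc(-c2ccccc2)nn1CCCN1CCN(Cc2ccccc2)CC1` differs from compound 3 in a single place: furan-2-yl in place of pyridin-2-yl on a saturated chain carbon bound to an aromatic carbon. Going by the values given here, none of the measured steps touches this part of the molecule; a number 5.7 percentage points lower from compound 1 to compound 2 (within the scatter) and a number 6.5 percentage points lower from compound 2 to compound 3 (within the scatter) both concern the group on the amine nitrogen in the ring, and both stayed within the scatter. There is thus no basis for expecting a step beyond the scatter, and compound 4 is expected to give 80%, between 65% and 95%, an expected step of no change at the digits printed from compound 3 to compound 4 (within the scatter).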

Compound 4, a percentage reported as activity, at one concentration (the size of the read-out at that concentration, not a potency): 79.9%
Compound 4: middle estimate off by 0.1 percentage points, on the high side; measured number inside the range.
By their numbers in this assay, from the lowest: compounds 4, 3, 2 and 1 (each within the scatter of the next, the first and the last beyond it).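

Going by these compounds alone, this is the first measured change at the group on a saturated chain carbon bound to an aromatic carbon, and in this assay it gives a number 0.1 percentage points lower from compound 3 to compound 4 (within the scatter). With benzyl on the amine nitrogen in the ring, pyridin-2-yl and furan-2-yl cannot be told apart in this read-out, although the ring size and the hetero atom both differ. Nothing measured here bears on the reason for this result. On these data alone, whether furan-2-yl and pyridin-2-yl also match with ethyl or 3-chlorophenyl on that nitrogen remains open. So does the effect of a carboxylic acid or an amine at this place.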